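Acetamido in Place of Trifluoromethyl: an Untested Step

A few compounds are considered here, and "the series" means these few. Any claim that something is new, unique, unknown or untested is made for them only; others in the source may bear on it.

Of the compounds shown here, two have so far been measured in a functional assay on HepG2 cells (Homo sapiens) for cytotoxicity, read by MTT assay, with a stated time of 24 h; on this read-out higher numbers stand for weaker inhibition and lower numbers for stronger inhibition. Compound 1 `O=C1/C(=C/c2cccc(F)c2)CN(S(=O)(=O)c2ccc(C(F)(F)F)cc2)C/C1=C\c1cccc(F)c1` gives 2400 nM there, and compound 2 `O=C1/C(=C/c2ccc(F)cc2)CN(S(=O)(=O)c2ccc(C(F)(F)F)cc2)C/C1=C\c1ccc(F)cc1` gives 3200 nM. Compound 2 has the highest of the two numbers, yet its gap to compound 1 lies within the scatter, so the two cannot be told apart on this evidence. Compound 3 `CC(=O)Nc1ccc(S(=O)(=O)N2C/C(=C\c3ccc(F)cc3)C(=O)/C(=C/c3ccc(F)cc3)C2)cc1` has not yet been measured. It differs from compound 2 in one place: acetamido in place of trifluoromethyl on an aromatic carbon. Among the compounds with values here, no pair of measured compounds shows this exchange, and the two values in hand only say that compound 1 and compound 2 sit within the scatter of each other. With nothing to guide the direction, the step from compound 2 to compound 3 is expected to be small, as a 1.3-fold higher number from compound 2 to compound 3 (0.10 log units; within the scatter), with wide bounds. Compound 3 is therefore estimated at 4000 nM, in a range from 1500 nM to 12000 nM.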

Compound 3, half-maximal inhibitory concentration: 7400 nM
Estimate against measurement, compound 3: 1.9-fold (0.27 log units) below; the measured number falls inside the stated range.
By their numbers in this assay, from the lowest: compounds 1 and 2 (each within the scatter of the next); then compound 3.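

Acetamido in place of trifluoromethyl on this aromatic carbon, para to a large group, gives a 2.3-fold higher number from compound 2 to compound 3 (0.36 log units; beyond the scatter) in this assay, which means weaker inhibition. The earlier compounds shown here both carry trifluoromethyl there, so they could say nothing about this position; it now proves able to move the read-out beyond the scatter, though only modestly and only in this single exchange. Nothing available accounts for the direction of the step, and the trifluoromethyl and acetamido groups differ in their atoms and in the hydrogen-bond donor and acceptor counted for acetamido, with no way to separate these here.

As far as these compounds go, it remains open how an amine, a carboxylic acid or a methoxy group on the same carbon would read. Also open, from the compounds shown here alone, is whether acetamido would shift the number in the same direction on the core of compound 1.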